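Swapping Acetyl for Dimethylamino on a Pyrazole Series

The source may report more compounds than this note shows. Statements on the series, on what has been measured and on what is new or still open speak of the compounds shown alone.

The account concerns two measured compounds and one untested analogue. Within the data shown here, in a functional assay on SNB-75 cells (Homo sapiens) for cytotoxicity, read by sulforhodamine B assay, with a stated time of 48 h, tested at 1 uM (a lower number here means a stronger effect, a higher number a weaker effect of the compound at the concentration tested), compound 1 `COc1cc(C)cc(-c2c(-c3ccnc(-c4ccc(C(C)=O)cc4)c3)cnn2CC#N)c1` gives -5%, the higher of the two numbers known so far. Compound 2 `Cc1cc(O)cc(-c2nn(CC#N)cc2-c2ccnc(-c3ccc(N(C)C)cc3)c2)c1` gives -22% in this assay, a number lying beyond the usual scatter below that of compound 1. Among the measured compounds shown here, no single-point step between the two measured compounds can be drawn, since they differ in more than one place.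

Compound 3 `COc1cc(C)cc(-c2c(-c3ccnc(-c4ccc(N(C)C)cc4)c3)cnn2CC#N)c1` is the untested analogue. It differs from compound 1 in one place: dimethylamino in place of acetyl on an aromatic carbon, on an aromatic carbon of a six-membered aromatic ring of carbon only, para to a large group. Compound 2 also carries the dimethylamino group and sits lower in this assay, but its second aryl group differs from that of compound 1, so no pattern can be claimed. The step from compound 1 to compound 3 is expected to be modest and downward, a number 9 percentage points lower from compound 1 to compound 3 (within the scatter), close to the edge of the scatter. For compound 3 the expected value in this assay is -14%, within a range from -35% to 8%.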

Compound 3, a percentage reported as activity, at one concentration (the size of the read-out at that concentration, not a potency): 10%
Compound 3: middle estimate off by 24 percentage points, on the low side; measured number above the stated range.
By their numbers in this assay, from the lowest: compound 2; then compound 1; then compound 3.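

Swapping 4-acetylphenyl for 4-(dimethylamino)phenyl gives the first one-place comparison in this set: in this assay, the change produces a number 15 percentage points higher from compound 1 to compound 3 (beyond the scatter). Since a higher number here means a weaker effect at the concentration tested, this position on the core of compound 1 is sensitive to the group it carries, and dimethylamino gives the weaker effect of the two groups compared. Nothing available here gives a reason for this step.

From the compounds shown here alone, it remains open whether other groups at this position, such as a primary amine, a carboxylic acid or a longer chain, would give numbers nearer to compound 1 or to compound 3. Going by these compounds, it also remains open whether this swap would move the number in the same direction on a different core or with a different second aryl group.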